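Pyrimidinyl for methoxyphenyl on the piperazine of compound 2

The source may hold more compounds than are shown below. What is called first, only, known or untested is meant among the compounds shown, and "the series" means these compounds.

Compound 1, `Nc1ccccc1NC(=O)c1ccc(CSC(=S)N2CCc3ccccc32)cc1`, gives 85.4% in a functional assay on A-375 cells (Homo sapiens) for antiproliferative activity, read by CCK-8 assay, with a stated time of 72 h, tested at 8 uM; a higher number here means a stronger effect of the compound at the concentration tested, a lower number a weaker effect.
Compound 2, `COc1ccc(N2CCN(C(=S)SCc3ccc(C(=O)Nc4ccccc4N)cc3)CC2)cc1`, gives 35.9%.
Compound 3, `CC1CCCCN1C(=S)SCc1ccc(C(=O)Nc2ccccc2N)cc1`, gives 85.2%.

The three measured compounds share one core and differ only in the group on the thiocarbonyl carbon. Compound 2 stands lowest of the three: the values of compound 1 and compound 3 lie far above it, beyond the scatter. Between the other two, the change of 2-methylpiperidin-1-yl for 2,3-dihydro-1H-indol-1-yl gives a number 0.2 percentage points lower from compound 1 to compound 3 (within the scatter), so those two groups behave alike here.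

Compound 4, `Nc1ccccc1NC(=O)c1ccc(CSC(=S)N2CCN(c3ncccn3)CC2)cc1`, keeps the piperazine of compound 2 and differs from it by pyrimidin-2-yl in place of 4-methoxyphenyl on an amine nitrogen in a ring. For the measured compounds named here, no measured step touches the group on this amine nitrogen in a ring; the only measured step concerns the thiocarbonyl carbon and was within the scatter, so it carries no guidance for this change. The expectation for compound 4 therefore rests on compound 2 alone, with a wide range. Compound 4 is estimated at 45%, between 20% and 75%. The expected step of a number 9.1 percentage points higher from compound 2 to compound 4 (within the scatter) is thus modest and uncertain in direction.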

Compound 4, a percentage reported as inhibition, at one concentration (the size of the read-out at that concentration, not a potency): 67.9%
Estimate against measurement, compound 4: 22.9 percentage points below, within the range that was stated.
By their numbers in this assay, from the lowest: compound 2; then compound 4; then compounds 3 and 1 (each within the scatter of the next).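

In this assay, for the compounds shown here, the group on the amine nitrogen in the ring proves able to move the read-out by a large amount, a point the earlier compounds could not show: the only step available before this one concerned the thiocarbonyl carbon and stayed within the scatter. Here the exchange of 4-methoxyphenyl, an aromatic ring of carbon only, for pyrimidin-2-yl, an aromatic ring with 2 hetero atoms, gives a clear rise (a number 32 percentage points higher from compound 2 to compound 4 (beyond the scatter)), while the six-membered ring with 2 nitrogen stays in place. Compound 2 and compound 4 both carry that ring, yet their numbers lie far apart. No measurement available here explains why this exchange raises the number.

Going by these compounds alone, the single step changes the methoxy group, the size of the aromatic ring and its ring atoms all at once, so it cannot say which of these matters. A plain phenyl or a pyridin-2-yl group on the same nitrogen would begin to separate these changes.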